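The source may hold more compounds than are shown below. What is called first, only, known or untested is meant among the compounds shown, and "the series" means these compounds.

Series notes. Among the compounds with values here, compound 1 `COc1ccc(-c2nc(C(=O)/C=C\Nc3ccc4[nH]ccc4c3)c3ccccn23)cc1` is one of two compounds measured so far in a functional assay on B16-F10 cells (Mus musculus) for cytotoxicity, read by MTT assay, with a stated time of 48 h; on this read-out lower numbers stand for stronger inhibition and higher numbers for weaker inhibition; compound 1 gives 5120 nM. The other measured compound, compound 2 `O=C(/C=C\Nc1cnc2ccccc2c1)c1nc(-c2ccccc2)n2ccccc12`, carries a different aryl group on the amine nitrogen and a phenyl in place of the methoxyphenyl on the shared core, and in this assay compound 2 gives 3780 nM. Compound 1 has the higher of the two numbers, but the gap to compound 2 is within the usual scatter of this assay, so the two values are read as equivalent rather than ordered.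

Compound 3 `COc1ccc(-c2nc(C(=O)/C=C\Nc3ccc(Cl)cc3)c3ccccn23)cc1` has not yet been measured in this assay. Relative to compound 1 the change is 4-chlorophenyl in place of 1H-indol-5-yl on an amine nitrogen. Within the data shown here, no measured pair differs only at this position, so there is no step on record to size this change against; the two measured compounds only show that different aryl groups on the amine nitrogen have so far given numbers that lie within scatter of each other.

Accordingly the step from compound 1 to compound 3 is expected to be a 1.0-fold lower number from compound 1 to compound 3 (0.01 log units; within the scatter), that is none beyond the scatter in either direction. Compound 3 is estimated at 5000 nM in this assay, within a range of 2000 nM to 13000 nM.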

Compound 3, half-maximal inhibitory concentration: 1240 nM
Estimate against measurement, compound 3: 4.0-fold (0.61 log units) above; measured number outside the range, below it.
By their numbers in this assay, from the lowest: compound 3; then compounds 2 and 1 (each within the scatter of the next).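

Within the data shown here, exchanging 1H-indol-5-yl for 4-chlorophenyl on the amine nitrogen gives a 4.1-fold lower number from compound 1 to compound 3 (0.62 log units; beyond the scatter) in this assay, the first single-place step on record for this series. The aryl group at this position therefore has a readable effect on the number, which compounds 1 and 2 could not show, as they differ in two places and lie within scatter of each other. The change removes a five-membered aromatic ring and a hydrogen-bond donor and introduces a chlorine, and this one step does not separate these differences; no measurement at hand explains the lower number.

Going by these compounds, it remains open whether the chlorine itself matters or whether the loss of the fused ring is enough, which a plain phenyl, a 4-fluorophenyl or a 4-methoxyphenyl on the amine nitrogen would help to settle. Also open, on these data alone, is whether 4-chlorophenyl in place of 1H-indol-5-yl gives a step of similar size on a core carrying phenyl instead of methoxyphenyl.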